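Acyl chain variation on the shared core: cytotoxicity notes

The source may hold more compounds than are shown below. What is called first, only, known or untested is meant among the compounds shown, and "the series" means these compounds.

Measured compounds:
compound 1 `CCCC(=O)Nc1ccn([C@@H]2CO[C@H](CO)O2)c(=O)n1` — 8070 nM
compound 2 `CCCCCCCCCCCCCCCC(=O)Nc1ccn([C@@H]2CO[C@H](CO)O2)c(=O)n1` — 20 nM

In a functional assay on SW1573 cells (Homo sapiens) for cytotoxicity, read by sulforhodamine B assay, with a stated time of 72 h (a lower number here means a stronger inhibitor, a higher number a weaker inhibitor), compound 1 gives 8070 nM, the highest number of the two shown. Compound 2 gives 20 nM, a far lower number, and the gap between the two lies well beyond the scatter. Within the data shown here, no measured pair differs in only one place, so no single-change step is available.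

Compound 3 `O=C(Nc1ccn([C@@H]2CO[C@H](CO)O2)c(=O)n1)C1CC1` carries cyclopropyl in place of propyl on a carbonyl carbon. Among the measured compounds shown here, nothing among the measured compounds shows what closing a short chain into a small ring does; the one large gap, from compound 1 to compound 2, comes with a far longer acyl chain, which compound 3 does not have. From compound 1 to compound 3 a step within the scatter is expected, a 1.1-fold higher number from compound 1 to compound 3 (0.05 log units; within the scatter). Compound 3 is expected near 9000 nM, in a range from 3000 nM to 30000 nM.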

Compound 3, half-maximal inhibitory concentration: 22000 nM
Compound 3: middle estimate off by 2.4-fold (0.39 log units), on the low side; measured number inside the range.
By their numbers in this assay, from the lowest: compound 2; then compound 1; then compound 3.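

In this assay, among these compounds, closing the propyl group on the carbonyl carbon into cyclopropyl is not a neutral swap: the first single-change reading at this position gives a 2.7-fold higher number from compound 1 to compound 3 (0.44 log units; beyond the scatter), a modest step. The carbon count of the group stays the same, so this step comes with the entry of a three-membered ring and not with any added carbon, which sets it apart from the much larger gap that accompanies the far longer acyl chain of compound 2. Nothing at hand explains why the ring raises the number.

Open, going by these compounds, is whether a larger ring, such as cyclobutyl, or a branched isopropyl group on the same carbonyl carbon would give a similar step. Also open, on these data alone, is how an intermediate chain, such as octyl, would fall on the shared core.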